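Microsomal clearance notes: from compound 2 to compound 3

The source may hold more compounds than are shown below. What is called first, only, known or untested is meant among the compounds shown, and "the series" means these compounds.

Compound 1 `NCCCCCOc1ccc([C@H]2CC[C@]3(CC2)OOC2(O3)C3CC4CC(C3)CC2C4)cc1`: < 7 mL.min-1.g-1 (a limit)
Compound 2 `N[C@H]1CC[C@H](Oc2ccc([C@H]3CC[C@]4(CC3)OOC3(O4)C4CC5CC(C4)CC3C5)cc2)CC1`: < 7 mL.min-1.g-1 (a limit)

Compound 2 gives < 7 mL.min-1.g-1 in an ADME assay on microsomes from liver (Homo sapiens) for metabolic stability, read by LC-MS, tested at 1 uM (a higher number here means faster removal of the compound, a lower number slower removal), as a limit. Compound 3 `NC(=O)C1CCN(Cc2ccc([C@H]3CC[C@]4(CC3)OOC3(O4)C4CC5CC(C4)CC3C5)cc2)CC1` arises through (4-carbamoylpiperidin-1-yl)methyl in place of (4-aminocyclohexyl)oxy on an aromatic carbon with the shared core unchanged. Among the compounds with values here, the only measured step, a step that the two limits leave unreadable from compound 1 to compound 2, offers no size to carry over, and the limit of < 7 mL.min-1.g-1 in this assay, at which 2 of the 2 values shown sit, covers both measured compounds. The change also differs from that step in kind, so the evidence is thin. Expected in this assay is an at least 1.1-fold higher number from compound 2 to compound 3 (0.05 log units; that floor lies within the scatter) with no direction beyond the scatter, though the upper end stays wide. For compound 3 the estimated value is 8 mL.min-1.g-1 with an expected range from 4 mL.min-1.g-1 to 25 mL.min-1.g-1 in these notes.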

Compound 3, intrinsic clearance in microsomes: 10 mL.min-1.g-1
Compound 3: the middle estimate sits 1.3-fold (0.10 log units) below what was measured; measured number inside the range.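

In this assay compound 3 gives 10 mL.min-1.g-1, the only number shown at this position that is not a limit: the limit of < 7 mL.min-1.g-1 in this assay, at which 2 of the 3 values shown sit. Replacing either ether-linked amine with (4-carbamoylpiperidin-1-yl)methyl gives an at least 1.4-fold higher number from compound 2 to compound 3 (0.15 log units; that floor lies within the scatter) and an at least 1.4-fold higher number from compound 1 to compound 3 (0.15 log units; that floor lies within the scatter), so neither step establishes a rise beyond the scatter. The step between the two limits cannot be read.

From the compounds shown here alone, how far compound 3 really stands from compound 1 and compound 2 stays open. Also open, going by these compounds, is how a carboxylic acid or a primary amine in place of the carbamoyl group would read in this assay.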